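Moving a Hydroxyl Around the Phenyl Ring

The source may report more compounds than this note shows. Statements on the series, on what has been measured and on what is new or still open speak of the compounds shown alone.

Of the compounds shown here, three sharing one core have been tested in a functional assay on HeLa cells (Homo sapiens) for cytotoxicity, read by CCK-8 assay; a higher number here means a weaker inhibitor, a lower number a stronger inhibitor. Compound 1 `Oc1ccc(-c2cc(-c3ccoc3)cc(-c3cccc(O)c3)n2)cc1` gives 3310 nM in this assay, and compound 2 `Oc1ccc(-c2cc(-c3ccccn3)cc(-c3cccc(O)c3)n2)cc1` gives 1930 nM; the step of a 1.7-fold lower number from compound 1 to compound 2 (0.23 log units; within the scatter) alters only the five- or six-membered ring that is neither hydroxyphenyl. One of the values shown is a limit: the limit of > 50000 nM in this assay, at which 1 of the 3 values shown sits. That value belongs to compound 3 `Oc1ccc(-c2cc(-c3cccnc3)cc(-c3ccccc3O)n2)cc1`, which gives > 50000 nM, a limit of the assay rather than a number. Compound 4 `Oc1ccc(-c2cc(-c3cccnc3)cc(-c3cccc(O)c3)n2)cc1` differs from compound 3 by 3-hydroxyphenyl in place of 2-hydroxyphenyl on an aromatic carbon. Within the data shown here, no measured step alters a hydroxyphenyl group, so none speaks directly to this change. Compounds 1 and 2, however, both carry the 3-hydroxyphenyl group of compound 4 and give numbers rather than limits. Compound 4 is therefore expected near them, at about 2500 nM (range 1000 nM to 10000 nM), an expected step of an at least 20-fold lower number from compound 3 to compound 4 (1.30 log units; beyond the scatter).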

Compound 4, half-maximal inhibitory concentration: > 50000 nM
Compound 4: only a limit was reported (the forecaster's own chance of this, stated with the estimate: 10%); middle value at least 20-fold (1.30 log units) away from the limit.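

So the 3-hydroxyphenyl group does not by itself secure a measurable number: the other ring also counts, with pyridin-3-yl in that place giving an at least 25-fold higher number from compound 2 to compound 4 (1.41 log units; beyond the scatter) and an at least 15-fold higher number from compound 1 to compound 4 (1.17 log units; beyond the scatter). Furan-3-yl and pyridin-2-yl had shown no such difference, with a 1.7-fold lower number from compound 1 to compound 2 (0.23 log units; within the scatter). The step from compound 3 to compound 4 cannot be read, so moving the hydroxyl has no measured effect here.

Still open, as far as these compounds go, is whether 2-hydroxyphenyl gives a number when paired with pyridin-2-yl. Also open, from the compounds shown here alone, is what a pyridin-4-yl or plain phenyl ring would give in place of pyridin-3-yl.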